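From vinyl to phenyl on the chain carbon

This account rests on a few compounds, and the source may have more. Where it says the series, first, only, none or still open, it means among the compounds named here.

Compound 1 `C=CCOC(=O)Nc1ccc([Se]C#N)cc1` in a functional assay on PC-3 cells (Homo sapiens) for cytotoxicity, read by MTT assay, with a stated time of 72 h (a higher number here means a weaker inhibitor of growth, a lower number a stronger inhibitor of growth), gives 44700 nM. Compound 3 `N#C[Se]c1ccc(NC(=O)Oc2ccccc2)cc1` gives 37500 nM and compound 2 `O=C(Nc1ccc([Se][Se]c2ccc(NC(=O)Oc3ccc(F)cc3)cc2)cc1)Oc1ccc(F)cc1` gives 31300 nM; compound 1 sits at the upper end of these three numbers, yet both of the others lie within the usual scatter of it. Compound 4 `N#C[Se]c1ccc(NC(=O)OCc2ccccc2)cc1` differs from compound 1 by phenyl in place of vinyl on a saturated chain carbon bound to an oxygen next to a carbonyl group. For the measured compounds named here, the one measured step that bears on this is a 1.2-fold lower number from compound 1 to compound 3 (0.08 log units; within the scatter), where a phenyl also took the place of the allyl, there on the oxygen. That step stayed within the scatter, so no change beyond the scatter is expected in this assay for compound 4 either. Compound 4 is therefore estimated to give 40000 nM, between 20000 nM and 80000 nM, which is an expected step of a 1.1-fold lower number from compound 1 to compound 4 (0.05 log units; within the scatter).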

Compound 4, concentration for total growth inhibition: 27800 nM
Beside the measured number, compound 4's estimate is 1.4-fold (0.16 log units) above it; the measured number falls inside the stated range.
By their numbers in this assay, from the lowest: compounds 4, 2, 3 and 1 (each within the scatter of the next).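

In this assay, phenyl in place of vinyl on this saturated chain carbon gives a 1.6-fold lower number from compound 1 to compound 4 (0.21 log units; within the scatter) and so stays within the scatter. This place therefore carries a six-membered aromatic ring as well as the vinyl, with no change beyond the scatter, which the earlier step on the oxygen could not show. No measured property bears on this result.

On these data alone, what an amine or a carboxylic acid in place of the phenyl, or a longer chain here, would give in this assay stays open. So does whether any group at this place can move the number beyond the scatter.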